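The compounds below may be only part of what the source reports. "The series", "measured", "known", "first", "only" and "open" are said of these compounds alone.

Compound 1 `Nc1ncnn2c([C@@H]3O[C@H](CO)[C@@H](O)[C@H]3O)cc(-c3ccccc3)c12`: > 100000 nM (a limit)
Compound 2 `Nc1ncnn2c([C@@H]3O[C@H](CO)[C@@H](O)[C@H]3O)cc(-c3ccc(F)cc3)c12`: 55500 nM

Among the compounds with values here, in a functional assay on NCI-H460 cells (Homo sapiens) for antiproliferative activity, with a stated time of 72 h (on this read-out lower numbers stand for stronger inhibition and higher numbers for weaker inhibition), compound 2 holds the only actual number so far. Compound 1 sits at the limit of > 100000 nM in this assay, at which 1 of the 2 values shown sits, which is a limit and not a number.

Compound 3 `Nc1ncnn2c([C@@H]3O[C@H](CO)[C@@H](O)[C@H]3O)cc(-c3ccsc3)c12` is the next to be read. The change is thiophen-3-yl in place of 4-fluorophenyl on an aromatic carbon.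

Within the data shown here, only one measured step touches this substituent: an at least 1.8-fold lower number from compound 1 to compound 2 (0.25 log units; that floor lies within the scatter). It exchanges fluoro for hydrogen and not one ring for another, so it gives only a loose guide to size and none to direction in this assay. The anchor therefore stays compound 2 at 55500 nM. The estimated step is a 1.4-fold lower number from compound 2 to compound 3 (0.14 log units; within the scatter), so no move beyond the scatter is expected. For compound 3 the expected value is 40000 nM, with an estimated range of 5000 nM to 100000 nM.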

Compound 3, half-maximal inhibitory concentration: 35600 nM
The estimate for compound 3 lay 1.1-fold (0.05 log units) above the measured number, within the range that was stated.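

In this assay, thiophen-3-yl in place of 4-fluorophenyl on this aromatic carbon gives a 1.6-fold lower number from compound 2 to compound 3 (0.19 log units; within the scatter), so a five-membered aromatic ring with a sulfur atom and the six-membered fluorinated ring cannot be told apart here. Against phenyl, thiophen-3-yl gives an at least 2.8-fold lower number from compound 1 to compound 3 (0.44 log units; beyond the scatter), the first step at this position to pass beyond the scatter, and its size is only a floor. Compound 1 stands at > 100000 nM, which is a limit and not a number: the limit of > 100000 nM in this assay, at which 1 of the 3 values shown sits.

On these data alone, whether thiophen-2-yl, a pyridine ring or a phenyl ring carrying an amine or a carboxylic acid on this carbon would separate from compound 3 stays open. Also open, as far as these compounds go, is how a change in the group of 9 heavy atoms on the shared core would read in this assay.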